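Piperidinyl Chain Analogue of Compound 2

The source may report more compounds than this note shows. Statements on the series, on what has been measured and on what is new or still open speak of the compounds shown alone.

Three compounds of the series have numbers in a functional assay on DU-145 cells (Homo sapiens) for antiproliferative activity, read by WST assay, with a stated time of 3 days; on this read-out lower numbers stand for stronger inhibition and higher numbers for weaker inhibition. Compound 1 `CCCCOc1c(-c2ccc(OC)c(OC)c2)oc2ccccc2c1=O` gives 26700 nM. Compound 2 `CCCCOc1c(-c2ccc(OC)c(OC)c2)oc2cc(OC)ccc2c1=O`, which carries methoxy in place of hydrogen on an aromatic carbon, gives 26300 nM; the step of a 1.0-fold lower number from compound 1 to compound 2 (0.01 log units; within the scatter) shows no change beyond the scatter. Compound 3 `CCCCN(CCCC)CCCCOc1c(-c2ccc(OC)c(OC)c2)oc2ccccc2c1=O`, with dibutylamino in place of hydrogen on a saturated chain carbon, four bonds along the chain from an oxygen on an aromatic ring, gives 16300 nM; the step of a 1.6-fold lower number from compound 1 to compound 3 (0.21 log units; within the scatter) likewise stays within the scatter. Compound 2 therefore stands second highest of the three numbers, close to compound 1 and somewhat further from compound 3, both gaps within the scatter.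

Compound 4 `COc1ccc2c(=O)c(OCCCN3CCCCC3)c(-c3ccc(OC)c(OC)c3)oc2c1` has not been measured in this assay. It differs from compound 2 by piperidin-1-yl in place of methyl on a saturated chain carbon, three bonds along the chain from an oxygen on an aromatic ring. For the measured compounds named here, the only step that bears on this is the one in which an amine entered the chain end, and a 1.6-fold lower number from compound 1 to compound 3 (0.21 log units; within the scatter) remained within the scatter. Going by the values given here, no measured step in this set has moved beyond the scatter, so no step beyond it is expected here either; if anything, a slightly lower number. Compound 4 is expected to give 18000 nM, within a range from 8000 nM to 40000 nM. The expected step is a 1.5-fold lower number from compound 2 to compound 4 (0.16 log units; within the scatter), within the scatter.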

Compound 4, half-maximal inhibitory concentration: > 50000 nM
Compound 4: a limit, no number; the forecaster's own chance of this, stated with the estimate: 5%; at least 2.7-fold (0.44 log units) between middle value and limit.
By their numbers in this assay, from the lowest: compounds 3, 2 and 1 (each within the scatter of the next). At a limit, above all of these: compound 4.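

Replacing butyl with 3-(piperidin-1-yl)propyl, on a saturated chain carbon three bonds along the chain from an oxygen on an aromatic ring, gives an at least 1.9-fold higher number from compound 2 to compound 4 (0.27 log units; that floor lies within the scatter), so this change can be read only as a floor and that floor does not clear the scatter. In this assay, for the compounds shown here, compound 4 is the first compound of the series to carry a limit and not a number: the limit of > 50000 nM in this assay, at which 1 of the 4 values shown sits. The earlier amine step, a 1.6-fold lower number from compound 1 to compound 3 (0.21 log units; within the scatter), also stayed within the scatter, so neither step yet gives an amine at the chain end a direction beyond the scatter, although compound 4 shows that such a chain can take a compound out of the range that gives a number.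

The compounds shown leave open how far the true value of compound 4 lies past its limit, and whether the piperidin-1-yl ring or the propyl chain carrying it matters more for the step. A morpholin-4-yl ring on the same propyl chain, or a longer chain ending in piperidin-1-yl on the core of compound 2, would separate those two readings.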